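A few compounds are considered here, and "the series" means these few. Any claim that something is new, unique, unknown or untested is made for them only; others in the source may bear on it.

Measured so far:
Compound 1, `Nc1nc(-c2ccccc2)cc(-c2cnn(-c3ccccc3)n2)n1`: in a functional assay on HL-60 cells (Homo sapiens) for inhibition, read by MTT assay (on this read-out lower numbers stand for stronger inhibition and higher numbers for weaker inhibition), compound 1 gives 66500 nM.
Compound 2, `Nc1nc(-c2ccc([N+](=O)[O-])cc2)cc(-c2cnn(-c3ccccc3)n2)n1`: in this assay compound 2 gives only a limit, > 200000 nM.

For the measured compounds named here, compound 2 stands at the limit of > 200000 nM in this assay, at which 1 of the 2 values shown sits; of the two values shown, it is the one without a number. Going by the values given here, the single measured step, an at least 3.0-fold higher number from compound 1 to compound 2 (0.47 log units; beyond the scatter), is the one that bears on the present change, as it adds the nitro group that compound 3 now loses.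

Compound 3, `Nc1ccc(-c2cc(-c3cnn(-c4ccccc4)n3)nc(N)n2)cc1`, differs from compound 2 by amino in place of nitro on an aromatic carbon, placed para to a large group. The nitro group entering moved the number toward weaker inhibition in the measured step, so its removal is expected to bring compound 3 back toward the region of compound 1. Among the compounds with values here, the amino group that enters has no measured counterpart in this set, so its own contribution is unknown. The expected step is an at least 4.0-fold lower number from compound 2 to compound 3 (0.60 log units; beyond the scatter), in the direction of stronger inhibition. For compound 3 the estimate in this assay is 50000 nM, with a range from 15000 nM to 200000 nM.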

Compound 3, half-maximal inhibitory concentration: 68200 nM
Compound 3: middle estimate off by 1.4-fold (0.13 log units), on the low side; low and high end bracket the measured number.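

Notes on the position para to a large group, read in this assay: amino in place of hydrogen gives a 1.0-fold higher number from compound 1 to compound 3 (0.01 log units; within the scatter), so compound 1 and compound 3 read as equal and this position carries amino with no visible cost or gain. Among the three groups seen here, nitro alone separates from the others, as the return from it to amino gives an at least 2.9-fold lower number from compound 2 to compound 3 (0.46 log units; beyond the scatter), which places the loss of inhibition with nitro specifically and not with any substituent at this position. The size of that separation remains a bound and not a number, since compound 2 is recorded only as a limit: the limit of > 200000 nM in this assay, at which 1 of the 3 values shown sits.

Still open, from the compounds shown here alone, is whether the match between hydrogen and amino holds for other groups at this position, such as methoxy, chlorine, a carboxylic acid or an acetamide, and whether any of them moves the number toward stronger inhibition than the shared core gives. Also open, going by these compounds, is how far compound 2 really lies past its limit, and whether the same order of groups would hold at another place on this phenyl ring.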